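One More Methoxy Group: From Compound 2 to Compound 3

The source may report more compounds than this note shows. Statements on the series, on what has been measured and on what is new or still open speak of the compounds shown alone.

Compound 1 `COc1ccc(-c2cc(/C=C/C(=O)c3cc(OC)c(OC)c(OC)c3)[nH]n2)cc1OC`: 1620 nM
Compound 2 `COc1ccc(C(=O)/C=C/c2cc(-c3cc(OC)c(OC)c(OC)c3)n[nH]2)cc1OC`: 2690 nM

Both numbers come from a functional assay on OVCAR-4 cells (Homo sapiens) for inhibition, read by sulforhodamine B assay, with a stated time of 48 h; a higher number here means a weaker inhibitor of growth, a lower number a stronger inhibitor of growth. Compound 2 gives 2690 nM, the highest of the two, while compound 1 at 1620 nM lies within the scatter of it, so the two cannot be ordered. Compound 3 `COc1cc(C(=O)/C=C/c2cc(-c3cc(OC)c(OC)c(OC)c3)n[nH]2)cc(OC)c1OC` differs from compound 2 by methoxy in place of hydrogen on an aromatic carbon. Going by the values given here, no measured pair shows this change, so its size is not known from these data. The step is expected to be small, a 1.8-fold lower number from compound 2 to compound 3 (0.25 log units; within the scatter), toward a somewhat lower number or none beyond the scatter. Compound 3 is expected to give about 1500 nM, within a range from 500 nM to 4500 nM.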

Compound 3, concentration for 50% growth inhibition: 1450 nM
For compound 3 the middle estimate is 1.0-fold (0.01 log units) above the measured one; the range from low to high includes it.
By their numbers in this assay, from the lowest: compounds 3, 1 and 2 (each within the scatter of the next).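

In this assay methoxy in place of hydrogen on an aromatic carbon now appears as a measured step twice, once on each of the two six-membered aromatic rings (a 1.9-fold lower number from compound 2 to compound 3 (0.27 log units; within the scatter)) and (a 1.1-fold lower number from compound 1 to compound 3 (0.05 log units; within the scatter)). Both steps lie within the scatter, so at neither place does the added methoxy show a measurable effect on growth inhibition. Nothing measured here bears on the reason. On these data alone, whether an amine or a carboxylic acid on these aromatic carbons, or a longer chain such as ethoxy, would move the number beyond the scatter stays open.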